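A few compounds are considered here, and "the series" means these few. Any claim that something is new, unique, unknown or untested is made for them only; others in the source may bear on it.

Three compounds built on a shared core have been examined in an assay on isolated protein for binding affinity to histamine H2 receptor (Homo sapiens); on this read-out lower numbers stand for stronger inhibition and higher numbers for weaker inhibition. Compound 1 `CC(=O)c1ccc(OCCCN2CC[C@H](NC(=O)c3csc(-c4cccnc4)n3)C2)cc1` gives 6200 nM in this assay, compound 3 `CC(=O)c1ccc(OCCCN2CC[C@H](NC(=O)c3cccnc3)C2)cc1` gives 3500 nM, and compound 2 `O=C(c1ccc(OCCCN2CC[C@H](NS(=O)(=O)c3ccccc3F)C2)cc1)C1CC1` gives 1550 nM. Compound 2 therefore shows the lowest number of the three, and both of its gaps, to compound 3 and to compound 1, lie beyond the usual scatter of the assay, so it is the strongest binder in this small set. Among the compounds with values here, the two weaker compounds carry amides on the shared core, whereas compound 2 carries a sulfonamide; with only one example of each kind, nothing firm can be read from that.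

Compound 4 `O=C(c1ccc(OCCCN2CC[C@H](NS(=O)(=O)c3cccc(F)c3)C2)cc1)C1CC1` keeps everything of compound 2 except the fluorophenyl group on the sulfonyl sulfur, which is rearranged: 3-fluorophenyl in place of 2-fluorophenyl on a sulfonyl sulfur. Within the data shown here, no measured pair in the set shows what such a shift of a fluorine does here, so the step cannot be anchored on data. In the absence of any pattern, the expectation is a step that stays within the scatter, in no particular direction. Compound 4 is thus estimated to give 1600 nM in this assay, with a range from 500 nM to 5000 nM. This estimate amounts to an expected step of a 1.0-fold higher number from compound 2 to compound 4 (0.01 log units; within the scatter).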

Compound 4, inhibition constant: 1600 nM
Compound 4: middle estimate and measured number agree at the digits printed; the measured number falls inside the stated range.
By their numbers in this assay, from the lowest: compounds 2 and 4 (each within the scatter of the next); then compounds 3 and 1 (each within the scatter of the next).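

In this assay, within the data shown here, the pair gives the first direct reading at this position, where 3-fluorophenyl in place of 2-fluorophenyl on a sulfonyl sulfur gives a 1.0-fold higher number from compound 2 to compound 4 (0.01 log units; within the scatter). Compounds 2 and 4 therefore cannot be told apart in this assay, so for this pair, the two fluorine placements on the ring make no difference that the measurement can detect. No separate measurement is available to explain how these two compounds compare.

As far as these compounds go, whether the fluorine matters at all remains open, since a plain phenyl group, a 3-chlorophenyl group or a small methyl group on the sulfonyl sulfur could read alike or could fall well away from compounds 2 and 4. From the compounds shown here alone, what the sulfonamide itself contributes is also open. Compounds 2 and 4 differ from the amides, compounds 1 and 3, in more than one place, with a cyclopropyl ketone rather than a methyl ketone at the far end of the molecule, so those gaps cannot be read as steps.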